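This account rests on a few compounds, and the source may have more. Where it says the series, first, only, none or still open, it means among the compounds named here.

In an ADME assay on NHDF cells (Homo sapiens) for cytotoxicity, read by MTT assay, with a stated time of 72 h (on this read-out lower numbers stand for stronger inhibition and higher numbers for weaker inhibition), compound 1 (`COc1ccccc1/C=C1\CCC/C(=C\c2cccc(OC)c2OC)C1=O`) gives 31300 nM as its result, compound 2 (`COc1ccc(/C=C2\CCC/C(=C\c3ccccc3Br)C2=O)cc1OC`) gives 21800 nM as its result and compound 3 (`COc1ccc(/C=C2\CCC/C(=C\c3ccc(Br)cc3)C2=O)cc1OC`) gives 13100 nM as its result. Compound 3 therefore cannot be told apart from compound 2, but its number lies beyond the scatter under that of compound 1.

The change in going to compound 4 (`COc1ccc(/C=C2\CCC/C(=C\c3cccc(Cl)c3Cl)C2=O)cc1OC`) is 2,3-dichlorophenyl in place of 4-bromophenyl on a double-bonded chain carbon bound to a double-bonded ring carbon and the rest of the molecule stays the same. In words, 2,3-dichlorophenyl takes the place of 4-bromophenyl on a double-bonded chain carbon bound to a double-bonded ring carbon.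

Within the data shown here, the only measured step that bears on this is a 1.7-fold lower number from compound 2 to compound 3 (0.22 log units; within the scatter) for 4-bromophenyl in place of 2-bromophenyl at that same carbon, and it lies within the scatter. Among the measured compounds shown here, no measured compound carries chlorine, so the data offer no direct guide to the 2,3-dichlorophenyl group.

For the measured compounds named here, with only that small step to go on, the expected move is a 1.4-fold higher number from compound 3 to compound 4 (0.14 log units; within the scatter) in this assay and no shift beyond the scatter is expected. For compound 4 the estimated value is 18000 nM with an expected range from 9000 nM to 36000 nM as the likely span.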

Compound 4, half-maximal inhibitory concentration: 18500 nM
For compound 4 the middle estimate is 1.0-fold (0.01 log units) below the measured one; low and high end bracket the measured number.
By their numbers in this assay, from the lowest: compounds 3, 4, 2 and 1 (each within the scatter of the next, the first and the last beyond it).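

In this assay, the 2,3-dichlorophenyl group can replace a bromophenyl group on the double-bonded chain carbon without a shift beyond the scatter: replacing 4-bromophenyl gives a 1.4-fold higher number from compound 3 to compound 4 (0.15 log units; within the scatter), and replacing 2-bromophenyl gives a 1.2-fold lower number from compound 2 to compound 4 (0.07 log units; within the scatter). Together with the earlier bromine comparison, this means that compound 2, compound 3 and compound 4 cannot be told apart by either step involving the new compound, so this cell read-out does not separate these three halogen-bearing phenyl groups, even though the halogen element and the pattern on the ring both differ. No measurement is available that would explain this result or link it to any property of these groups.

Each of these steps changes the halogen element and its placement together, so the separate contribution of each remains unresolved. Going by these compounds, it also remains open whether a phenyl group carrying an amine or a carboxylic acid, or a longer chain in place of the phenyl group at this carbon, would move the number beyond the scatter.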